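The compounds below may be only part of what the source reports. "The series", "measured", "known", "first", "only" and "open" are said of these compounds alone.

Measured so far:
compound 1 `CCN1CCCC1CNC(=O)c1cc(N(C)S(=O)(=O)N(C)C)ccc1OC` — 1 mg/kg
compound 2 `CCN1CCCC1CNC(=O)c1cc(NS(=O)(=O)NC)ccc1OC` — > 1 mg/kg

In a functional assay on the whole organism for inhibition, with Canis familiaris (Canis lupus familiaris) as the target (a lower number here means that less compound is needed, a higher number that more compound is needed for the effect), compound 1 gives 1 mg/kg. For compound 2 only a limit of this assay is known, > 1 mg/kg. Among the compounds with values here, the one recorded step, a number no lower from compound 1 to compound 2 (the limit leaves the size open), therefore cannot be sized, as the limit of > 1 mg/kg in this assay, at which 1 of the 2 values shown sits, shows. Compound 3 `CCN1CCCC1CNC(=O)c1cc(NS(N)(=O)=O)ccc1OC` differs from compound 2 by hydrogen in place of methyl on a sulfonamide nitrogen. Within the data shown here, no measured step covers this change, so the expectation rests on where compound 2 stands, at its limit. Compound 3 is estimated at 2 mg/kg, with a range of 1 mg/kg to 6 mg/kg. The expected step reads a step that the limit leaves unreadable from compound 2 to compound 3, with a fair chance that only a limit is again reported.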

Compound 3, dose for half-maximal effect: 10 mg/kg
For compound 3 the middle estimate is 5.0-fold (0.70 log units) below the measured one, and the stated range ends below it.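

In this assay, sulfamoylamino in place of (dimethylsulfamoyl)(methyl)amino on an aromatic carbon gives a 10-fold higher number from compound 1 to compound 3 (1.00 log units; beyond the scatter) and so puts the first readable size on a change at this position. The value for compound 2 is a limit, so the steps involving it cannot be read: the limit of > 1 mg/kg in this assay, at which 1 of the 3 values shown sits.

Still open, from the compounds shown here alone, is which of the methyl groups lost between compound 1 and compound 3 carries the step. Also open, going by these compounds, is how an ethyl group or a longer chain on a sulfonamide nitrogen would read in this assay on the shared core.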